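The compounds below may be only part of what the source reports. "The series", "measured", "known", "first", "only" and "open" are said of these compounds alone.

Compound 1 `CN(C)c1nc(N)sc1C(=O)c1cnc2ccccn12`: 32%
Compound 2 `Cc1cccn2c(C(=O)c3sc(N)nc3N(C)C)cnc12`: 81%
Compound 3 `Cc1ccn2c(C(=O)c3sc(N)nc3N(C)C)cnc2c1`: 85%

In a functional assay on the whole organism (strain Sprague-Dawley) for inhibition, with Rattus norvegicus as the target, read by paw edema, with stated times of 1 h and 3 h, at a dose of 50 mg/kg by the oral route (on this read-out lower numbers stand for less inhibition and higher numbers for more inhibition at the one dose given (going by the name of the read-out)), compound 1 stands lowest of the three numbers; compound 2 and compound 3 both lie well above it, beyond the scatter. Compound 4 `Cc1ccc2ncc(C(=O)c3sc(N)nc3N(C)C)n2c1` differs from compound 1 by methyl in place of hydrogen on an aromatic carbon. For the measured compounds named here, two measured steps bear on this change, both of the same kind, a methyl in place of hydrogen on an aromatic carbon of the shared core: a number 49 percentage points higher from compound 1 to compound 2 (beyond the scatter) and a number 53 percentage points higher from compound 1 to compound 3 (beyond the scatter). Both are large upward steps. The methyl in compound 4 sits at a different place from those in compound 2 and compound 3, which leaves the expectation less firm, but a large upward step in this assay is still expected. Compound 4 is therefore estimated at 75%, within a range of 50% to 90%, which would mean an expected step of a number 43 percentage points higher from compound 1 to compound 4 (beyond the scatter).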

Compound 4, a percentage reported as inhibition, in the whole organism at one dose (the size of the read-out at that dose, not a potency): 23%
For compound 4 the middle estimate is 52 percentage points above the measured one, outside the stated range (below it).
By their numbers in this assay, from the lowest: compounds 4 and 1 (each within the scatter of the next); then compounds 2 and 3 (each within the scatter of the next).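

In this assay, methyl in place of hydrogen at this carbon, two atoms from the ring nitrogen, gives a number 9 percentage points lower from compound 1 to compound 4 (within the scatter). The same kind of change elsewhere on the shared core gave a number 49 percentage points higher from compound 1 to compound 2 (beyond the scatter) and a number 53 percentage points higher from compound 1 to compound 3 (beyond the scatter), so among these compounds the large rise depends on where the methyl sits and does not come with every methyl on this ring. Nothing available explains why this place behaves differently.

The compounds shown leave open whether a methoxy group or an amine at this same carbon would leave the number unmoved, as methyl does.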